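Aryl group variation on the piperidine nitrogen

The compounds below may be only part of what the source reports. "The series", "measured", "known", "first", "only" and "open" are said of these compounds alone.

Measured compounds:
- compound 1: `COC(=O)C1=C(C)N=C(C)/C(=C(/O)OC)C1c1cccc(NC(=O)NCCNC2CCN(c3ccccc3O)CC2)c1`, 6 nM
- compound 2: `COC(=O)C1=C(C)N=C(C)/C(=C(/O)OC)C1c1cccc(NC(=O)NCCNC2CCN(c3cccc(Cl)c3)CC2)c1`, 8 nM

In an assay on SK-N-MC cells for inhibition of Neuropeptide Y receptor type 1 (Homo sapiens) (on this read-out lower numbers stand for stronger inhibition and higher numbers for weaker inhibition), compound 1 gives 6 nM and compound 2 gives 8 nM. For the measured compounds named here, compound 2 holds the higher of the two numbers, but the only step between them, a 1.3-fold higher number from compound 1 to compound 2 (0.12 log units; within the scatter), lies within the scatter, so the two cannot be ranked.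

Compound 3 is `COC(=O)C1=C(C)N=C(C)/C(=C(/O)OC)C1c1cccc(NC(=O)NCCNC2CCN(c3ccccc3SC)CC2)c1`. The change from compound 2 is 2-(methylsulfanyl)phenyl in place of 3-chlorophenyl on an amine nitrogen in a ring. Going by the values given here, the single measured step at this same position, a 1.3-fold higher number from compound 1 to compound 2 (0.12 log units; within the scatter), exchanged a 2-hydroxyphenyl for a 3-chlorophenyl without moving the number beyond the scatter. On that evidence alone, a second exchange of the aryl group at this nitrogen is expected to leave the read-out essentially where compound 2 stands, with an expected step of a 1.1-fold lower number from compound 2 to compound 3 (0.06 log units; within the scatter). Compound 3 is therefore estimated at 7 nM, with a range from 3 nM to 18 nM.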

Compound 3, half-maximal inhibitory concentration: 5 nM
Compound 3: the middle estimate sits 1.4-fold (0.15 log units) above what was measured; measured number inside the range.
By their numbers in this assay, from the lowest: compounds 3, 1 and 2 (each within the scatter of the next).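

In this assay, for the compounds shown here, 2-(methylsulfanyl)phenyl in place of 3-chlorophenyl gives a 1.6-fold lower number from compound 2 to compound 3 (0.20 log units; within the scatter), and methylsulfanyl in place of hydroxy on an aromatic carbon gives a 1.2-fold lower number from compound 1 to compound 3 (0.08 log units; within the scatter), so all three aryl groups on this amine nitrogen remain unresolved from one another, with no compound in the set going against that reading. The second step adds what the first did not show: with the 2-position of the phenyl kept, hydroxy and methylsulfanyl are not told apart, and 2-(methylsulfanyl)phenyl, with 1 hydrogen-bond acceptor, is not told apart from 3-chlorophenyl, with 0. Nothing available bears on why these groups read alike.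

Still open, as far as these compounds go, is whether the read-out stays at this level with a carboxylic acid or a primary amine on the phenyl ring. Also open, from the compounds shown here alone, is whether an aromatic ring is needed on this nitrogen at all, as a plain methyl or a benzyl group would show.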